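The compounds below may be only part of what the source reports. "The series", "measured", "known", "first", "only" and "open" are said of these compounds alone.

- compound 1 `Cc1ccc(S(=O)(=O)Oc2cccc(/C=C(\C#N)C(=O)Nc3nnc(C)s3)c2)cc1`: 27%
- compound 2 `COc1ccc(-c2nnc(NC(=O)/C(C#N)=C/c3cccc(OS(=O)(=O)c4ccc(C)cc4)c3)s2)cc1`: "not toxic" (no number reported)

In an ADME assay on HEK-293T cells (Homo sapiens) for inhibition, read by CCK-8 assay, with a stated time of 48 h, tested at 20 uM (a lower number here means less inhibition of growth, a higher number more inhibition of growth at the concentration tested), compound 2 has no single number and is reported only as "not toxic" (no number reported), so it cannot be placed numerically against compound 1 at 27%. The next compound, still unmeasured, is compound 3 `Cc1ccc(S(=O)(=O)Oc2cccc(/C=C(\C#N)C(=O)Nc3nnc(-c4ccccc4Cl)s3)c2)cc1`. The change 2-chlorophenyl in place of 4-methoxyphenyl on an aromatic carbon puts 2-chlorophenyl in place of 4-methoxyphenyl on an aromatic carbon. Among the compounds with values here, no measured pair shows what such a change does, so the expected step in this assay is none beyond the usual scatter. For compound 3 the estimated value is 18%, with an expected range from 0% to 38%.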

Compound 3, percent growth inhibition at one concentration: 55%
The estimate for compound 3 lay 37 percentage points below the measured number, outside the stated range (above it).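

In this assay, the group on this ring carbon clearly matters: 2-chlorophenyl in place of methyl gives a number 28 percentage points higher from compound 1 to compound 3 (beyond the scatter), so a substituted phenyl group here can raise growth inhibition in these cells. Compound 2, with 4-methoxyphenyl at the same place, is reported only as "not toxic", so its step to compound 3 cannot be read, although that wording suggests that not every substituted phenyl group behaves alike. No measurement here explains the rise. Whether the chlorine or the phenyl ring accounts for it remains open, as does the outcome with a plain phenyl group or an amine at this carbon.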